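The source may hold more compounds than are shown below. What is called first, only, known or untested is meant among the compounds shown, and "the series" means these compounds.

In an assay on cells for displacement of a labelled ligand from adenosine receptor A3 (Homo sapiens), read by scintillation counting, with a stated time of 3 h (on this read-out higher numbers stand for weaker inhibition and lower numbers for stronger inhibition), compound 3 `Nc1nc(-c2ccc(O)cc2)cn2c(=O)n(-c3ccccc3)nc12` gives 53 nM, the lowest of the two numbers recorded here. Compound 2 `O=c1[nH]c(-c2ccc(O)cc2)cn2c(=O)n(-c3ccccc3)nc12` gives 207 nM in this assay. Compound 1 `CCCOc1ccc(-c2cn3c(=O)n(-c4ccccc4)nc3c(N)n2)cc1` reaches only a limit of this assay, > 30000 nM, which is not a number. Among the measured compounds shown here, the step of an at least 560-fold lower number from compound 1 to compound 3 (2.75 log units; beyond the scatter) is the one measured change at this oxygen. Compound 4 `C#CCOc1ccc(-c2cn3c(=O)n(-c4ccccc4)nc3c(N)n2)cc1` differs from compound 3 by propargyl in place of hydrogen on an oxygen on an aromatic ring, so a chain again sits on that oxygen where compound 1 carried propyl. Because compound 1 sits at the limit of > 30000 nM in this assay, at which 1 of the 3 values shown sits, a large weakening step is expected, and the estimated 150-fold higher number from compound 3 to compound 4 (2.18 log units; beyond the scatter) points that way. Compound 4 is therefore expected to give about 8000 nM, between 800 nM and 30000 nM, with a fair chance that only a limit is reported.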

Compound 4, inhibition constant: > 30000 nM
Compound 4 gave a limit, no number; the forecaster's own chance of this, stated with the estimate: 45%; at least 3.7-fold (0.57 log units) between middle value and limit.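

In this assay, propargyl on this oxygen brings an at least 560-fold higher number from compound 3 to compound 4 (2.75 log units; beyond the scatter), so the large loss first seen with propyl is not confined to that one chain. Compound 4 joins compound 1 at a limit, which is not a number: the limit of > 30000 nM in this assay, at which 2 of the 4 values shown sit. The step between these two compounds cannot be read, so propyl and propargyl cannot be ranked against each other.

The compounds shown leave open whether a smaller group on this oxygen, such as methyl, would give a readable number. They also leave open how an amine in place of the hydroxy would compare with compound 3.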